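Swapping the trifluoromethylphenyl for a dichlorophenyl

A few compounds are considered here, and "the series" means these few. Any claim that something is new, unique, unknown or untested is made for them only; others in the source may bear on it.

Compound 1 `COc1cc2cc(Oc3ccc(NC(=O)Nc4ccc(C(F)(F)F)cc4)cc3)c(C)nc2cc1OC` is measured in a functional assay on MOLT-4 cells (Homo sapiens) for inhibition, read by sulforhodamine B assay, with a stated time of 48 h, tested at 10 uM (a lower number here means a stronger effect, a higher number a weaker effect of the compound at the concentration tested), and gives 61.9%, the highest of the two numbers in hand. Compound 2 `COc1cc2cc(Oc3ccc(NC(=O)Nc4ccc(Cl)c(C(F)(F)F)c4)cc3)c(C)nc2cc1OC` gives -27.9% in this assay. Compound 3 `COc1cc2cc(Oc3ccc(NC(=O)Nc4ccc(Cl)c(Cl)c4)cc3)c(C)nc2cc1OC` differs from compound 1 by 3,4-dichlorophenyl in place of 4-(trifluoromethyl)phenyl on an amide-type nitrogen. Among the compounds with values here, the one measured step that bears on this, a number 89.8 percentage points lower from compound 1 to compound 2 (beyond the scatter), also brings a chloro group onto that ring and is large. A sizeable drop is therefore expected, a number 56.9 percentage points lower from compound 1 to compound 3 (beyond the scatter), though smaller than that step because compound 2, with -27.9%, keeps a trifluoromethyl group. Compound 3 is estimated at 5%, between -40% and 50%.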

Compound 3, a percentage reported as activity, at one concentration (the size of the read-out at that concentration, not a potency): 3.69%
Compound 3: the middle estimate sits 1.3 percentage points above what was measured, and the stated range covers the measured number.
By their numbers in this assay, from the lowest: compound 2; then compound 3; then compound 1.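

In this assay, 3,4-dichlorophenyl in place of 4-(trifluoromethyl)phenyl on the amide-type nitrogen gives a number 58.2 percentage points lower from compound 1 to compound 3 (beyond the scatter), so a strong effect at this position does not require a trifluoromethyl group. Still, chloro in place of trifluoromethyl on an aromatic carbon gives a number 31.6 percentage points higher from compound 2 to compound 3 (beyond the scatter), so this swap loses part of the effect of compound 2. Nothing measured here explains why either change has this effect. Open, going by these compounds, is how 4-chlorophenyl, or a nitrile or an amine on that ring, would compare with compound 3.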